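Methyl Swapped for Trifluoromethyl on the Benzylsulfanyl Arm

This account rests on a few compounds, and the source may have more. Where it says the series, first, only, none or still open, it means among the compounds named here.

Of the compounds shown here, three that share one core have been measured in an ADME assay on microsomes from liver (Homo sapiens) for metabolic stability, read by LC-MS, using NADPH, tested at 5 uM; on this read-out lower numbers stand for a shorter-lived compound and higher numbers for a longer-lived compound. Compound 1 `Cc1cccc(CSc2cc(Cl)c(C)cc2S(=O)(=O)/N=C(\N)n2nccc2-c2ccccc2)c1` gives 0.232 h. Compound 2 `Cc1cc(-c2ccccc2)n(/C(N)=N/S(=O)(=O)c2cc(C)c(Cl)cc2SCc2cccc3ccccc23)n1` gives 0.256 h, and compound 3 `Cc1cc(S(=O)(=O)/N=C(\N)n2nccc2-c2ccccc2)c(SCc2cccc(Cl)c2)cc1Cl` gives 0.309 h. Compound 1 carries the lowest of the three numbers, yet its gaps to compound 2 and to compound 3 both fall within the scatter, so no ranking among them can be read from these values. Within the data shown here, the single one-point step measured so far, a 1.3-fold higher number from compound 1 to compound 3 (0.12 log units; within the scatter), moved the number by less than the scatter.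

Compound 4 `Cc1cc(S(=O)(=O)/N=C(\N)n2nccc2-c2ccccc2)c(SCc2ccc(C(F)(F)F)cc2)cc1Cl` differs from compound 1 by 4-(trifluoromethyl)phenyl in place of 3-methylphenyl on a saturated chain carbon bound to a sulfur. Among the measured compounds shown here, no measured pair shows this exact exchange, so it cannot be calibrated directly; the only other alteration of the (3-methylbenzyl)sulfanyl group, from compound 1 to compound 3, stayed within the scatter. On that basis the expected step in this assay is a 1.2-fold higher number from compound 1 to compound 4 (0.07 log units; within the scatter), which amounts to no change beyond the scatter in either direction. Compound 4 is therefore estimated at 0.27 h, with a range from 0.13 h to 0.55 h.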

Compound 4, half-life: 0.176 h
Beside the measured number, compound 4's estimate is 1.5-fold (0.19 log units) above it; the measured number falls inside the stated range.
By their numbers in this assay, from the lowest: compounds 4, 1, 2 and 3 (each within the scatter of the next).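

This position, on a saturated chain carbon bound to a sulfur, now has three aryl groups on an otherwise identical compound in this assay, and the new exchange is the largest yet made there, with 10 heavy atoms entering for 7 leaving (a 1.3-fold lower number from compound 1 to compound 4 (0.12 log units; within the scatter)). Set against the 3-chlorophenyl group, the 4-(trifluoromethyl)phenyl group also stays inside the scatter (a 1.8-fold lower number from compound 3 to compound 4 (0.24 log units; within the scatter)), so among compounds 1, 3 and 4 no exchange at this place separates from the others, and none of the three goes against that reading. Nothing available here explains these numbers, so the small size of the steps is all that can be stated.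

This exchange alters both the substituent and where it sits on the phenyl ring, so a 3-(trifluoromethyl)phenyl or a 4-methylphenyl group would be needed to tell those two changes apart. From the compounds shown here alone, whether this place stays as flat with a different kind of group, such as an amine or a carboxylic acid on the phenyl ring, or a longer chain in place of the benzyl carbon, remains open.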